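A Smaller Group on the Shared Core

The compounds below may be only part of what the source reports. "The series", "measured", "known", "first", "only" and "open" are said of these compounds alone.

Measured so far:
Compound 1 `Cc1cc(Nc2cc(-c3ccccc3)[nH]n2)n2nc(SCc3csc4ccccc34)nc2n1` gives 4420 nM in a functional assay on PC-9 cells (Homo sapiens) for inhibition, read by MTT assay, with a stated time of 72 h; on this read-out higher numbers stand for weaker inhibition and lower numbers for stronger inhibition.
Compound 2 `CCCCCc1c(C)nc2nc(SCc3ccc(Cl)cc3)nn2c1Nc1cc(-c2ccccc2)[nH]n1` gives > 50000 nM in this assay, a limit of the assay rather than a number.

Compound 1 holds the only true number shown; the other value sits at the limit (the limit of > 50000 nM in this assay, at which 1 of the 2 values shown sits). Compound 3 `Cc1cc(Nc2cc(-c3ccccc3)[nH]n2)n2nc(SCC3CC3)nc2n1` differs from compound 1 in one place: cyclopropyl in place of 1-benzothiophen-3-yl on a saturated chain carbon bound to a sulfur. For the measured compounds named here, no step between measured compounds is available, so the size of this change is uncertain. Most of the sulfur-linked group is removed, and the expected step of a 3.4-fold higher number from compound 1 to compound 3 (0.53 log units; beyond the scatter) points toward weaker inhibition, beyond the usual scatter. Compound 3 is therefore estimated at 15000 nM, within a range from 4000 nM to 50000 nM.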

Compound 3, half-maximal inhibitory concentration: > 50000 nM
Compound 3: a limit, no number; the forecaster's own chance of this, stated with the estimate: 30%; middle value at least 3.3-fold (0.52 log units) from the limit.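

On the shared core, the group on the saturated chain carbon bound to a sulfur clearly matters: cyclopropyl in place of 1-benzothiophen-3-yl gives an at least 11-fold higher number from compound 1 to compound 3 (1.05 log units; beyond the scatter) in this assay. Going by these compounds, compound 3 gives > 50000 nM, which is a limit and not a number, so the true size of the step stays unknown. Compound 3 therefore adds to the values that cannot be ranked against each other: the limit of > 50000 nM in this assay, at which 2 of the 3 values shown sit.

On these data alone, how much of the 1-benzothiophen-3-yl group is needed remains open. A pyridine ring or a straight hexyl chain in its place could begin to show this.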